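Swapping 2-carboxyphenyl for 3-(methoxycarbonyl)phenyl on a shared core

This account rests on a few compounds, and the source may have more. Where it says the series, first, only, none or still open, it means among the compounds named here.

In a functional assay on SK-OV-3 cells (Homo sapiens) for inhibition, read by CCK-8 assay, with a stated time of 70 h (on this read-out higher numbers stand for weaker inhibition and lower numbers for stronger inhibition), compound 1 (`Clc1ccc(COc2ccc(OCCOCCNC3CCCC3)cc2)cc1`) gives 7670 nM as a measured number. Compound 2 (`O=C(O)c1ccccc1COc1ccc(OCCOCCNC2CCCC2)cc1`) gives > 100000 nM as a limit, not a number. Compound 3 (`COC(=O)c1cccc(COc2ccc(OCCOCCNC3CCCC3)cc2)c1`) has 3-(methoxycarbonyl)phenyl in place of 2-carboxyphenyl (3-(methoxycarbonyl)phenyl in place of 2-carboxyphenyl on a saturated chain carbon bound to an oxygen on an aromatic ring) on the same saturated chain carbon. For the measured compounds named here, the only measured step (an at least 13-fold higher number from compound 1 to compound 2 (1.11 log units; beyond the scatter)) brought in the 2-carboxyphenyl group and was large, so removing that group is expected to reverse much of it. Expected in this assay is an at least 6.6-fold lower number from compound 2 to compound 3 (0.82 log units; beyond the scatter) (a lower number, meaning stronger inhibition). Compound 3 is estimated at 15000 nM (expected range 4000 nM to 60000 nM).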

Compound 3, half-maximal inhibitory concentration: 45500 nM
Compound 3: middle estimate off by 3.0-fold (0.48 log units), on the low side; low and high end bracket the measured number.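

The change to 3-(methoxycarbonyl)phenyl gives an at least 2.1-fold lower number from compound 2 to compound 3 (0.34 log units; beyond the scatter), so a measured number returns at this place on the saturated chain carbon. The group still does not match 4-chlorophenyl, with a 5.9-fold higher number from compound 1 to compound 3 (0.77 log units; beyond the scatter). Compound 2 has only a limit, not a number, so the true size of the gain from it cannot be read: the limit of > 100000 nM in this assay, at which 1 of the 3 values shown sits.

2-carboxyphenyl and 3-(methoxycarbonyl)phenyl differ in both the substituent and its ring position, and these two effects remain unseparated. A 3-carboxyphenyl group would keep the position and change only the substituent.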